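Swapping One Group on a Well-Tolerated Core

The source may hold more compounds than are shown below. What is called first, only, known or untested is meant among the compounds shown, and "the series" means these compounds.

Compound 1 `Cc1nc(N)nc2c1ncn2[C@@H]1O[C@H](CO)[C@@H](O)[C@@]1(C)O`, compound 2 `COc1nc(Cl)nc2c1ncn2[C@@H]1O[C@H](CO)[C@@H](O)[C@@]1(C)O` and compound 3 `C[C@@]1(O)[C@H](O)[C@@H](CO)O[C@H]1n1cnc2c(N)nc(NN)nc21` share one core and have been tested in an ADME assay on PBMC cells (Homo sapiens) for cytotoxicity, with a stated time of 5 days; a lower number here means that less compound is tolerated, a higher number that more compound is tolerated. In this assay compound 1 gives > 100000 nM, a limit of the assay and not a number. Compound 2 also gives a limit, > 100000 nM. Compound 3 likewise stands at a limit, > 100000 nM. Taken together, the results so far amount to the limit of > 100000 nM in this assay, at which 3 of the 3 values shown sit.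

Compound 4 `C[C@@]1(O)[C@H](O)[C@@H](CO)O[C@H]1n1cnc2c(N)nc(N=[N+]=[N-])nc21` has not yet been measured. It carries azido in place of the aminoamino group of compound 3 on an aromatic carbon, between two ring nitrogen atoms: azido in place of aminoamino on an aromatic carbon. Among the measured compounds shown here, no measured pair of compounds shows the size of a single structural step, so the expectation rests on the limit of compound 3, > 100000 nM. The expected step is a number no higher from compound 3 to compound 4 (the limit leaves the size open), which means none beyond the usual scatter in this assay. The estimate for compound 4 is 100000 nM, with an expected range from 40000 nM to 100000 nM.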

Compound 4, half-maximal cytotoxic concentration: > 100000 nM
Compound 4: a limit, no number; the forecaster's own chance of this, stated with the estimate: 75%; the middle value lies on the limit itself.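

Compound 3 and compound 4 both give only a limit of the assay in this assay, so the change to azido in place of aminoamino yields no readable step: the limit of > 100000 nM in this assay, at which 4 of the 4 values shown sit. The compounds shown leave open where the half-maximal cytotoxic concentration of any of them lies, and whether these two groups differ at all.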